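Changing the Group on the Aromatic Oxygen of Compound 3

The compounds below may be only part of what the source reports. "The series", "measured", "known", "first", "only" and "open" are said of these compounds alone.

Compound 1 `COC(=O)/C=C/c1cccc(N(Cc2ccc(/C=C/C(=O)OC(C)(C)C)cc2OC(C)=O)C(=O)C2CCCCC2)c1`, compound 2 `COC(=O)/C=C/c1cccc(N(Cc2ccc(/C=C/C(=O)OC(C)(C)C)cc2OC(=O)c2ccccc2)C(=O)C2CCCCC2)c1` and compound 3 `COC(=O)/C=C/c1cccc(N(Cc2ccc(/C=C/C(=O)OC(C)(C)C)cc2OS(C)(=O)=O)C(=O)C2CCCCC2)c1` share one core and differ only in the group carried on an oxygen on an aromatic ring. In an assay on isolated protein with Bile acid receptor (Homo sapiens) as the target (a lower number here means that less compound is needed, a higher number that more compound is needed for the effect), compound 1 reaches only the assay limit, > 1000 nM. Compound 2 likewise gives a limit, > 1000 nM. Compound 3 also gives a limit, > 1000 nM. The steps a step that the two limits leave unreadable from compound 1 to compound 2, a step that the two limits leave unreadable from compound 1 to compound 3 and a step that the two limits leave unreadable from compound 2 to compound 3 therefore cannot be sized, since (the limit of > 1000 nM in this assay, at which 3 of the 3 values shown sit). Compound 4 `CCOC(=O)COc1cc(/C=C/C(=O)OC(C)(C)C)ccc1CN(C(=O)C1CCCCC1)c1cccc(/C=C/C(=O)OC)c1` continues the series: (ethoxycarbonyl)methyl in place of methylsulfonyl on an oxygen on an aromatic ring. Among the compounds with values here, none of the measured steps offers a readable size, so the expected step that the limit leaves unreadable from compound 3 to compound 4 rests on the limits alone and is most likely none that can be seen. Compound 4 is estimated at 2000 nM, within 300 nM to 10000 nM, with another limit the likeliest outcome.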

Compound 4, half-maximal effective concentration: > 1000 nM
Compound 4 was reported as a limit (the forecaster's own chance of this, stated with the estimate: 70%); the middle value lies beyond the limit too.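

Compound 4 gives only a limit, > 1000 nM. Its steps from compound 1, compound 2 and compound 3 therefore cannot be read: the limit of > 1000 nM in this assay, at which 4 of the 4 values shown sit.

The compounds shown leave open whether any group on this oxygen changes the value in this assay, and by how much.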